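The source may report more compounds than this note shows. Statements on the series, on what has been measured and on what is new or still open speak of the compounds shown alone.

Two compounds have been measured so far in a functional assay on A549 cells (Homo sapiens) for antiproliferative activity, read by MTT assay, with a stated time of 48 h (a higher number here means a weaker inhibitor, a lower number a stronger inhibitor), with these results

Compound 1 `COc1cc(-c2nnc3c(OC4COC4)cc(-c4ccc5[nH]ccc5c4)cn23)cc(OC)c1OC` gives 9810 nM
Compound 2 `COc1cc(-c2nnc3c(OCC(F)(F)F)cc(-c4ccc5[nH]ccc5c4)cn23)cc(OC)c1OC` gives 585 nM

Compound 2 has the lower of the two numbers, which makes it the stronger inhibitor of this pair. The next compound, compound 3 `COc1cc(-c2nnc3c(OC4CCC4)cc(-c4ccc5[nH]ccc5c4)cn23)cc(OC)c1OC`, keeps the shared core and changes a single group, with cyclobutyl in place of 2,2,2-trifluoroethyl on an oxygen on an aromatic ring and nothing else altered.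

Going by the values given here, only one measured step bears on this change. It is a 17-fold lower number from compound 1 to compound 2 (1.22 log units; beyond the scatter) and it shows that the group on this oxygen can matter a great deal. Compound 1, at 9810 nM, also carries a ring on this oxygen, while the ring of compound 3 is of carbon only. One step cannot show which of these two features counts, so the expectation is loose. The expected change is a 1.9-fold higher number from compound 2 to compound 3 (0.27 log units; within the scatter) and it should lead to a moderately higher number, smaller than the measured step. For compound 3 the estimated value is 1100 nM with an expected range from 300 nM to 4000 nM as the outer ends.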

Compound 3, half-maximal inhibitory concentration: 232 nM
Compound 3: middle estimate off by 4.7-fold (0.68 log units), on the high side; the whole stated range lies above it.
By their numbers in this assay, from the lowest: compound 3; then compound 2; then compound 1.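

In this assay the cyclobutyl ring on this oxygen gives a lower number than the open 2,2,2-trifluoroethyl chain, with a 2.5-fold lower number from compound 2 to compound 3 (0.40 log units; beyond the scatter) beyond the scatter, so fluorine is not needed here to reach the lowest number among these compounds. Against the oxetan-3-yl group, which is also a ring on the same oxygen, the change is much larger, with a 42-fold lower number from compound 1 to compound 3 (1.63 log units; beyond the scatter) as the measured step, so having a ring does not by itself give a low number: the ring of carbon only stands lowest of the three and the oxetan-3-yl ring stands highest. Nothing available here explains why the three groups fall in this order.

The compounds shown leave open whether a larger carbon ring such as cyclopentyl, or a plain carbon chain such as isopropyl, would give a lower number still, and what a group carrying an amine would do on this oxygen. They also cannot tell whether the same order would hold if another part of the shared core were changed.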